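A few compounds are considered here, and "the series" means these few. Any claim that something is new, unique, unknown or untested is made for them only; others in the source may bear on it.

Measured compounds and their values:
compound 1, `COc1ccc(/C=C/C=C/C(=O)c2ccccc2)cc1`, > 100000 nM
compound 2, `COc1ccc(/C=C/C=C/C(=O)c2ccc(F)cc2)cc1`, "not determined" (no result reported)
compound 3, `COc1ccc(/C=C/C=C/C(=O)c2ccc(C)s2)cc1`, "not determined" (no result reported)

The three measured compounds share one core and differ only in the group attached to the carbonyl carbon. Among the measured compounds shown here, in an ADME assay on RAW264.7 cells (Mus musculus) for cytotoxicity, read by MTT assay (a lower number here means a stronger inhibitor, a higher number a weaker inhibitor), compound 1 gives only a limit of the assay, > 100000 nM, and that limit, (the limit of > 100000 nM in this assay, at which 1 of the 3 values shown sits), is the single piece of information this assay has produced for the series. For compound 2 no result was reported in this assay. Compound 3 likewise has no number in this assay; of the three values shown, one is a limit and one is an entry without a number, so compound 3 cannot be placed against any neighbour by measurement.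

Compound 4, `COc1ccc(/C=C/C=C/C(=O)c2cc(C)oc2C)cc1`, differs from compound 3 in one place: 2,5-dimethylfuran-3-yl in place of 5-methylthiophen-2-yl on a carbonyl carbon. For the measured compounds named here, no measured step between any pair of compounds exists to calibrate what this exchange does. With compound 1 sitting at the limit, the expectation for the step from compound 3 to compound 4 in this assay is no change beyond the usual scatter, in either direction, and most probably another limit rather than a number. Compound 4 is therefore estimated at 100000 nM, with a range of 30000 nM to 300000 nM.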

Compound 4, half-maximal inhibitory concentration: > 100000 nM
Compound 4: no number, only a limit; the forecaster's own chance of this, stated with the estimate: 70%; the middle value sits exactly at the limit.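

In this assay compound 4 gives > 100000 nM, which is a limit of the assay and not a number. No step can be read from compound 1 to compound 4, since both carry only a limit: the limit of > 100000 nM in this assay, at which 2 of the 4 values shown sit.

The compounds shown leave open whether any group on the carbonyl carbon gives a value inside the range of this assay.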